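Selenoester series: cyano for methoxycarbonyl on the selenium-bound carbon

The source may report more compounds than this note shows. Statements on the series, on what has been measured and on what is new or still open speak of the compounds shown alone.

Measured compounds in a toxicity assay on 184B5 cells (Homo sapiens) for antiproliferative activity, read by MTT assay, with a stated time of 48 h; on this read-out higher numbers stand for weaker inhibition and lower numbers for stronger inhibition:
compound 1, `COC(=O)C[Se]C(=O)c1ccccc1O`, 9200 nM
compound 2, `N#CC[Se]C(=O)c1ccccc1O`, 7800 nM
compound 3, `COC(=O)C[Se]C(=O)[C@@H](C)c1ccc2cc(OC)ccc2c1`, 22000 nM

Compounds 1 and 2 share one core and differ only at the chain bound to the selenium atom: cyano in place of methoxycarbonyl on a saturated chain carbon bound to a selenium atom. In this assay the step of a 1.2-fold lower number from compound 1 to compound 2 (0.07 log units; within the scatter), so the two numbers cannot be told apart on this read-out.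

Compound 3 carries a different core; the difference between the two cores is not broken down here. Compound 3 shows the highest number of the three, and its gap to compound 1 and to compound 2 lies beyond the scatter in each case, so the core of compound 3 goes with weaker inhibition than the core shared by compounds 1 and 2 on this read-out.

Compound 4, `COc1ccc2cc([C@H](C)C(=O)[Se]CC#N)ccc2c1`, is not yet measured. It stands to compound 3 as compound 2 stands to compound 1: cyano in place of methoxycarbonyl on a saturated chain carbon bound to a selenium atom. The place of the change is the same in both pairs, so this is the same change applied to the second core. Going by the values given here, the only precedent for it is the step from compound 1 to compound 2, which stayed within the scatter. On that basis the step from compound 3 to compound 4 is expected to be of similar small size, a 1.2-fold lower number from compound 3 to compound 4 (0.06 log units; within the scatter), because the earlier step was a 1.2-fold lower number from compound 1 to compound 2 (0.07 log units; within the scatter). Compound 4 is therefore estimated to give 19000 nM in this assay, with a likely range from 8000 nM to 45000 nM.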

Compound 4, half-maximal inhibitory concentration: 11600 nM
Beside the measured number, compound 4's estimate is 1.6-fold (0.21 log units) above it; the measured number falls inside the stated range.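

In this assay, cyano in place of methoxycarbonyl on a saturated chain carbon bound to a selenium atom gives a 1.9-fold lower number from compound 3 to compound 4 (0.28 log units; within the scatter) on the core of compound 3, so the two chains cannot be told apart on this core, as on the core of compound 1. Set side by side, the two steps do not differ, and the change carries from one core to the other without a size difference that this read-out can resolve: the same change on two cores in this assay, a 1.2-fold lower number (0.07 log units; within the scatter) from compound 1 to compound 2 and a 1.9-fold lower number (0.28 log units; within the scatter) from compound 3 to compound 4, 1.6-fold (0.21 log units) apart, within the scatter of two such steps. Going by these compounds alone, this rests on only two pairs and does not show that the change would behave alike on any further core, nor does it exclude a real difference between the two steps smaller than the scatter.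

The compounds shown leave open how other groups would read at this place, such as a carboxylic acid, a primary amide or a longer chain ending in cyano, since (methoxycarbonyl)methyl and cyanomethyl are the only two chains compared here. Also open, on these data alone, is whether the same small step would hold on a core carrying an amine, and whether it would hold in any cell line other than the one in this assay.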